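The source may report more compounds than this note shows. Statements on the series, on what has been measured and on what is new or still open speak of the compounds shown alone.

Measured compounds:

Compound 1, `Cc1cc(-c2nc3sc(C)cn3c2/C=N/NC(=N)N)c(C)s1`, in a functional assay on cells (Melanoma cell, Homo sapiens) for inhibition (on this read-out lower numbers stand for stronger inhibition of growth and higher numbers for weaker inhibition of growth), compound 1 gives 15100 nM.
Compound 2, `Cc1cn2c(/C=N/NC(=N)N)c(-c3cccs3)nc2s1`, in this assay compound 2 gives 5890 nM.
Compound 3, `Cc1cc(-c2nc3n(c2/C=N/NC(=N)N)CCS3)c(C)s1`, in this assay compound 3 gives 29500 nM.

Compounds 1 and 2 share a core and differ in a single place: thiophen-2-yl in place of 2,5-dimethylthiophen-3-yl on an aromatic carbon. This exchange gave a 2.6-fold lower number from compound 1 to compound 2 (0.41 log units; beyond the scatter). Compound 3 carries a different core; the difference between the core of compound 1 and the core of compound 3 is not broken down here. In this assay compound 3 gives the highest of the three numbers, but its gap to compound 1 lies within the usual scatter, so no order between those two can be read; its gap to compound 2 lies beyond the scatter.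

Compound 4, `N=C(N)N/N=C/c1c(-c2cccs2)nc2n1CCS2`, has not yet been measured in this assay. It differs from compound 3 in this way: thiophen-2-yl in place of 2,5-dimethylthiophen-3-yl on an aromatic carbon. The surroundings of the place are not worded identically for both pairs: for compound 3 and compound 4 the site is also two ring bonds from two ring atoms that each bear a fused ring, which is not said of compound 1 and compound 2. The change is therefore the same kind of change as that from compound 1 to compound 2, not the same one.

The estimate for compound 4 rests on the step of a 2.6-fold lower number from compound 1 to compound 2 (0.41 log units; beyond the scatter), carried over to the core of compound 3. Compound 4 is expected to show a step of a 2.6-fold lower number from compound 3 to compound 4 (0.41 log units; beyond the scatter). In this assay compound 4 is estimated at 11500 nM, with a range from 5000 nM to 26000 nM.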

Compound 4, concentration for total growth inhibition: 38000 nM
Estimate against measurement, compound 4: 3.3-fold (0.52 log units) below; the measured number lies above the stated range.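

Carried to the other core in this assay, the exchange of 2,5-dimethylthiophen-3-yl for thiophen-2-yl gave a 1.3-fold higher number from compound 3 to compound 4 (0.11 log units; within the scatter), so no order can be read between those two numbers, and the lower number seen on the first core did not recur. The two steps differ, which shows that in this series the result of this exchange on one core could not be transferred to the other: the same change on two cores in this assay, a 2.6-fold lower number (0.41 log units; beyond the scatter) from compound 1 to compound 2 and a 1.3-fold higher number (0.11 log units; within the scatter) from compound 3 to compound 4, 3.3-fold (0.52 log units) apart, beyond the scatter of two such steps. This does not show what in the cores separates the two results, and with a single pair on each core it does not show which of the two steps is the more typical for either core, nor whether the exchange would behave the same way on any further core.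

The compounds shown leave open how either core responds to other groups on this aromatic carbon, such as a phenyl ring, a furan-2-yl ring or an unsubstituted hydrogen, and so whether the difference between the cores is peculiar to the thiophene pair. They also leave open whether the two methyl groups of 2,5-dimethylthiophen-3-yl matter separately from the point at which the thiophene ring is attached, as a 2,5-dimethylthiophen-3-yl and a thiophen-2-yl differ in both.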